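This account rests on a few compounds, and the source may have more. Where it says the series, first, only, none or still open, it means among the compounds named here.

In a functional assay on EA.hy 926 cells (Homo sapiens) for cytotoxicity, read by MTT assay, with stated times of 24 h and 12 h, tested at 25 uM (on this read-out higher numbers stand for a stronger effect at the one concentration tested and lower numbers for a weaker effect), three compounds have been measured so far:

compound 1 `COc1ccc(OC(=O)c2nc(C)c(C)nc2C)c(/C=C/C(=O)O)c1` gives 45%
compound 2 `COc1cc(/C=C/C(=O)O)cc(OC)c1OC(=O)c1nc(C)c(C)nc1C` gives 24%
compound 3 `CCOC(=O)/C=C/c1cc(OC)c(OC(=O)c2nc(C)c(C)nc2C)c(OC)c1` gives 20.9%

Compound 1 stands highest of the three, and its gaps to compound 2 and compound 3 lie beyond the usual scatter. How the core of compound 1 differs from the core of compound 2 is not broken down here. Compound 3 differs from compound 2 by one change, (ethyl in place of hydrogen on an oxygen next to a carbonyl group), and that change gave a number 3.1 percentage points lower from compound 2 to compound 3 (within the scatter).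

Compound 4 `CCOC(=O)/C=C/c1cc(OC)ccc1OC(=O)c1nc(C)c(C)nc1C` has not been measured. It differs from compound 1 by the same change, (ethyl in place of hydrogen on an oxygen next to a carbonyl group), made at the same place; the change occurs twice among these compounds. Because a number 3.1 percentage points lower from compound 2 to compound 3 (within the scatter) stayed within the scatter, the step from compound 1 is expected to be small, a number 3 percentage points lower from compound 1 to compound 4 (within the scatter). Compound 4 is therefore estimated at 42% in this assay, expected to fall between 30% and 54%.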

Compound 4, a percentage reported as activity, at one concentration (the size of the read-out at that concentration, not a potency): 23.4%
Estimate against measurement, compound 4: 18.6 percentage points above, and the stated range ends above it.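

On the core of compound 1, putting ethyl in place of hydrogen on an oxygen next to a carbonyl group gave a number 21.6 percentage points lower from compound 1 to compound 4 (beyond the scatter), so the step seen on the core of compound 2 did not carry over in size. In this assay, the result of this change depends on the core that carries it: the same change on two cores in this assay, a number 3.1 percentage points lower (within the scatter) from compound 2 to compound 3 and a number 21.6 percentage points lower (beyond the scatter) from compound 1 to compound 4, 18.5 percentage points apart, beyond the scatter of two such steps. Among the compounds shown here, with only two pairs, this does not show which feature of the cores is responsible, or what size the step would take on a further core.

The compounds shown leave open how a methyl group or a longer chain such as butyl would compare with ethyl at that oxygen. They also leave open how an amide made from an amine would read on either core.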